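A few compounds are considered here, and "the series" means these few. Any claim that something is new, unique, unknown or untested is made for them only; others in the source may bear on it.

Measured so far in a functional assay on A549 cells (Homo sapiens) for inhibition, read by CCK-8 assay, with a stated time of 72 h, tested at 2 uM; a lower number here means less inhibition of growth, a higher number more inhibition of growth at the concentration tested:

- compound 1 `Cc1cc(C)cc(SCc2ccc(/C=C/C(=O)Nc3ccccc3N)cc2)c1`: 46.1%
- compound 2 `Nc1ccccc1NC(=O)/C=C/c1ccc(CSc2cccc(F)c2)cc1`: 50.7%
- compound 3 `CCc1ccc(SCc2ccc(C(=O)Nc3ccccc3N)cc2)cc1`: 53.6%

The numbers for these three compounds all lie within the usual scatter of one another, so compound 3, at 53.6%, cannot be ranked above the other two. The next compound is compound 4 `Nc1ccccc1NC(=O)c1ccc(CSc2ccc(Br)cc2)cc1`, which has bromo in place of ethyl on an aromatic carbon, turning 4-ethylphenyl into 4-bromophenyl: bromo in place of ethyl on an aromatic carbon.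

Among the compounds with values here, no compound measured so far carries bromo, so the evidence is indirect. Within the data shown here, one measured step bears on this change: a number 4.6 percentage points higher from compound 1 to compound 2 (within the scatter), where 3-fluorophenyl replaces 3,5-dimethylphenyl on a sulfur. That step also swaps carbon groups for a halogen, although on a core that differs from the core of compound 3. Since it stayed within the scatter, no real shift is expected in this assay here either. The expected step is a number 1.6 percentage points lower from compound 3 to compound 4 (within the scatter), which is within the scatter. For compound 4 the estimated value is 52%, with an expected range from 41% to 63%.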

Compound 4, percent growth inhibition at one concentration: 33.2%
The estimate for compound 4 lay 18.8 percentage points above the measured number, and the stated range ends above it.
By their numbers in this assay, from the lowest: compound 4; then compounds 1, 2 and 3 (each within the scatter of the next).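

Replacing ethyl with bromo at this position gives a number 20.4 percentage points lower from compound 3 to compound 4 (beyond the scatter) in this assay, so the group on this aromatic carbon, para to a large group, can change the result. The earlier step, a number 4.6 percentage points higher from compound 1 to compound 2 (within the scatter), also put a halogen in place of carbon groups but stayed within the scatter, on a different core and with a different substitution pattern, so that swap does not behave the same way everywhere. The data shown offer no measured explanation for the drop.

As far as these compounds go, it remains open whether a chloro, methoxy or amine group at this position would give a number closer to compound 3 or to compound 4. It is also unknown whether bromo would have the same effect on the core of compound 1.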